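A few compounds are considered here, and "the series" means these few. Any claim that something is new, unique, unknown or untested is made for them only; others in the source may bear on it.

Of the compounds shown here, three sharing one core have been measured in a functional assay on HeLa cells (Homo sapiens) for antiproliferative activity, read by MTT assay, with a stated time of 48 h; a higher number here means a weaker inhibitor, a lower number a stronger inhibitor. Compound 3 `COc1ccc2nc(Nc3ccnc(Nc4ccc(S(N)(=O)=O)cc4)n3)sc2c1` gives 1730 nM and holds the lowest of the three numbers. Compound 1 `Cc1ccc2nc(Nc3nc(Nc4ccc(S(N)(=O)=O)cc4)ncc3F)sc2c1` gives 1890 nM in this assay, a value that lies within the scatter of the value of compound 3, so the two cannot be told apart. Compound 2 `COc1ccc2nc(Nc3nc(Nc4ccc(S(N)(=O)=O)cc4)ncc3C)sc2c1` gives 36700 nM in this assay. Within the data shown here, the only measured step between compounds that differ in one place runs a 21-fold lower number from compound 2 to compound 3 (1.33 log units; beyond the scatter); it concerns a group on the shared core of compound 3, not the group that changes here.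

Compound 4 `Cc1ccc2nc(Nc3ccnc(Nc4ccc(S(N)(=O)=O)cc4)n3)sc2c1` has not yet been measured. It differs from compound 3 by methyl in place of methoxy on an aromatic carbon. Among the measured compounds shown here, no measured step touches this exchange directly. Compound 1 carries the methyl and compound 3 the methoxy, but they also differ in a second place, so their close values in this assay can only hint that the exchange is not large. The change from compound 3 to compound 4 is therefore expected to be a 1.0-fold lower number from compound 3 to compound 4 (0.01 log units; within the scatter), with no step beyond the scatter. In this assay compound 4 is expected to give about 1700 nM, within a range from 700 nM to 4500 nM.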

Compound 4, half-maximal inhibitory concentration: 660 nM
The estimate for compound 4 lay 2.6-fold (0.41 log units) above the measured number, and the stated range ends above it.
By their numbers in this assay, from the lowest: compound 4; then compounds 3 and 1 (each within the scatter of the next); then compound 2.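

In this assay, the exchange of methoxy for methyl now has a direct reading, a 2.6-fold lower number from compound 3 to compound 4 (0.42 log units; beyond the scatter), so the group at this place on the shared core changes the number by a modest step that lies beyond the scatter. The earlier compounds shown here offered no comparison in one place for this exchange. The second new step, a 2.9-fold lower number from compound 1 to compound 4 (0.46 log units; beyond the scatter), adds a reading at a different aromatic carbon and sits alongside the earlier step, a 21-fold lower number from compound 2 to compound 3 (1.33 log units; beyond the scatter): in both, hydrogen on that carbon gives the lower number, once against fluoro and once against methyl, and no step shown goes against this, though the two steps rest on different groups at the first place. Nothing available here accounts for either new step.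

As far as these compounds go, with only methoxy and methyl compared at the first place, it remains open how hydrogen, chloro, an amine or a longer chain such as ethoxy would behave there. From the compounds shown here alone, it is also open whether the step from methoxy to methyl keeps its size when fluoro or methyl sits on the other aromatic carbon.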